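This account rests on a few compounds, and the source may have more. Where it says the series, first, only, none or still open, it means among the compounds named here.

In a functional assay on HEK293 cells (Homo sapiens) for cytotoxicity (on this read-out lower numbers stand for higher toxicity in this test and higher numbers for lower toxicity in this test), compound 1 `COc1ccc([C@H]2CC(=O)N(c3cccc(O)c3)C2)cc1OC1CCCC1` gives > 10000 nM, which is a limit and not a number. Compound 2 `COc1ccc([C@H]2CC(=O)N(c3ccccc3N)C2)cc1OC1CCCC1` gives > 10000 nM, which is also a limit, so its place in the series is known only as a limit. Going by the values given here, the series so far stands at the limit of > 10000 nM in this assay, at which 2 of the 2 values shown sit.

The next change leads to compound 3 `COc1ccc([C@H]2CC(=O)N(c3ccccc3C)C2)cc1OC1CCCC1`, with methyl in place of amino on an aromatic carbon, ortho to a large group: methyl in place of amino on an aromatic carbon. Among the compounds with values here, the one measured step, a step that the two limits leave unreadable from compound 1 to compound 2, puts 2-aminophenyl in place of 3-hydroxyphenyl and offers no size to carry over. No step beyond the scatter is therefore expected in this assay, in either direction, and another limit reading is the likely outcome. The estimated change is a step that the limit leaves unreadable from compound 2 to compound 3. For compound 3 the expected value is 15000 nM, with an estimated range from 10000 nM to 40000 nM.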

Compound 3, half-maximal cytotoxic concentration: > 10000 nM
Compound 3 was reported as a limit (the forecaster's own chance of this, stated with the estimate: 90%); the middle value lies beyond the limit too.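

In this assay compound 3 gives > 10000 nM, a limit and not a number. Going by these compounds alone, no step to compound 3 from compound 1 or compound 2 can be read, and the series stands at one value: the limit of > 10000 nM in this assay, at which 3 of the 3 values shown sit. The compounds shown leave open whether compound 1, compound 2 and compound 3 differ in this read-out at all.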